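The compounds below may be only part of what the source reports. "The series", "measured", "known", "first", "only" and "open" are said of these compounds alone.

Compound 1 `Cc1ccc(-n2cc(COc3cccc4cnc(Nc5cccc(Cl)c5)nc34)nn2)c([N+](=O)[O-])c1` gives in a functional assay on MDA-MB-231 cells (Homo sapiens) for cytotoxicity, read by cell counting, with a stated time of 48 h (a lower number here means a stronger inhibitor, a higher number a weaker inhibitor), a limit, > 25000 nM.
Compound 2 `Clc1ccc(-n2cc(COc3cccc4cnc(Nc5cccc(Cl)c5)nc34)nn2)cc1` gives in this assay a limit, > 25000 nM.
Compound 3 `Clc1cccc(Nc2ncc3cccc(OCc4cn(-c5ccc(Br)cc5)nn4)c3n2)c1` gives in this assay 33000 nM.

Compound 1 thus stands only at a limit, as the limit of > 25000 nM in this assay, at which 2 of the 3 values shown sit, shows. The step to compound 4 `COc1cccc(-n2cc(COc3cccc4cnc(Nc5cccc(Cl)c5)nc34)nn2)c1` is 3-methoxyphenyl in place of 4-methyl-2-nitrophenyl on an aromatic nitrogen. The measured steps that touch the same aromatic nitrogen are a step that the two limits leave unreadable from compound 1 to compound 2 and a step that the limit leaves unreadable from compound 1 to compound 3, while a step that the limit leaves unreadable from compound 2 to compound 3 changes only the halogen; none of them is readable in size, and every value sits near or at the limit. No step beyond the scatter is therefore expected in this assay for compound 4, in either direction. Compound 4 is expected at 30000 nM, with a range from 10000 nM to 90000 nM, which is an expected step that the limit leaves unreadable from compound 1 to compound 4.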

Compound 4, half-maximal inhibitory concentration: 25000 nM
The estimate for compound 4 lay 1.2-fold (0.08 log units) above the measured number, within the range that was stated.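

Among the compounds shown here, with 3-methoxyphenyl in place of 4-bromophenyl on this aromatic nitrogen, this assay shows the first step at this position whose size can be read: a 1.3-fold lower number from compound 3 to compound 4 (0.12 log units; within the scatter). These two phenyl groups therefore cannot be told apart here. The other two new steps are a number no higher from compound 1 to compound 4 (the limit leaves the size open) and a number no higher from compound 2 to compound 4 (the limit leaves the size open). Their sizes cannot be read, because compound 1 and compound 2 stand only at a limit: the limit of > 25000 nM in this assay, at which 2 of the 4 values shown sit.

The compounds shown leave open whether a phenyl ring bearing an amine or a carboxylic acid would move the number beyond the scatter. They also leave open whether a longer carbon chain on this nitrogen, in place of the ring, would do so.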